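Swapping an Indole for a Carboxypiperidine on the Sulfonyl

The source may report more compounds than this note shows. Statements on the series, on what has been measured and on what is new or still open speak of the compounds shown alone.

Three compounds sharing one core were tested in an ADME assay on Vero cells (Chlorocebus sabaeus) for cytotoxicity, read by MTT assay; a higher number here means that more compound is tolerated, a lower number that less compound is tolerated. Compound 2 `Cn1nc(C(F)(F)F)cc1C(=O)Nc1ccc(S(=O)(=O)n2ccc3ccccc32)cc1` gives 13000 nM, the lower of the two plain numbers. Compound 1 `CCn1nc(C(F)(F)F)cc1C(=O)Nc1ccc(S(=O)(=O)N2CCCCC2C)cc1` gives 30000 nM, a gap from compound 2 that lies beyond the usual scatter. Compound 3 `Cn1nc(C(F)(F)F)cc1C(=O)Nc1ccc(S(=O)(=O)N2CCN(C(=O)OC(C)(C)C)CC2)cc1` reaches only a limit of the assay, > 300000 nM, which is a limit and not a number (the limit of > 300000 nM in this assay, at which 1 of the 3 values shown sits). Compound 4 `Cn1nc(C(F)(F)F)cc1C(=O)Nc1ccc(S(=O)(=O)N2CCCCC2C(=O)O)cc1` is not yet measured and differs from compound 2 in one place: 2-carboxypiperidin-1-yl in place of 1H-indol-1-yl on a sulfonyl sulfur. For the measured compounds named here, no measured pair shows this exact change. Compound 1 also carries a six-membered non-aromatic ring with one hetero atom on the sulfonyl sulfur and gives 30000 nM. On that basis an upward step of a 6.2-fold higher number from compound 2 to compound 4 (0.79 log units; beyond the scatter) is expected, beyond the scatter. Compound 4 is estimated at 80000 nM, expected to fall between 25000 nM and 300000 nM.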

Compound 4, half-maximal cytotoxic concentration: > 300000 nM
Compound 4 gave a limit, no number; the forecaster's own chance of this, stated with the estimate: 30%; middle value at least 3.7-fold (0.57 log units) from the limit.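

In this assay, putting 2-carboxypiperidin-1-yl in place of 1H-indol-1-yl on the sulfonyl sulfur gives an at least 23-fold higher number from compound 2 to compound 4 (1.36 log units; beyond the scatter). For the compounds shown here, this is the first one-place comparison at this position, and it shows that this group alone can shift the tolerated concentration by a large step. The value of compound 4 is a limit and not a number, so the step has a floor but no known size: the limit of > 300000 nM in this assay, at which 2 of the 4 values shown sit.

As far as these compounds go, it remains open whether the carboxylic acid or the non-aromatic ring carries this step. A plain piperidine or the methyl ester of the acid on the same core would separate the two.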